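The source may report more compounds than this note shows. Statements on the series, on what has been measured and on what is new or still open speak of the compounds shown alone.

Measured in an ADME assay on MT4 cells (Homo sapiens) for cytotoxicity, read by MTT assay; on this read-out higher numbers stand for lower toxicity in this test and lower numbers for higher toxicity in this test:
compound 1 `COc1cccc2c1c(C(=O)/C=C(\O)C(=O)O)cn2Cc1c(F)cccc1F` gives 44300 nM;
compound 2 `CCOC(=O)/C(O)=C/C(=O)c1cn(Cc2c(F)ccc(F)c2F)c2cccc(OC)c12` gives 40500 nM;
compound 3 `COc1cccc2c1c(C(=O)/C=C(\O)C(=O)O)cn2Cc1c(F)ccc(F)c1F` gives 49400 nM.

Compound 2 holds the lowest of the three numbers, yet its separations from compound 1 and from compound 3 both lie within the scatter, so the three compounds read alike in this assay. Compound 4 `CCOC(=O)/C(O)=C/C(=O)c1cn(Cc2cccc(F)c2F)c2cccc(OC)c12` is not yet measured. Against compound 2 it carries hydrogen in place of fluoro on an aromatic carbon. Going by the values given here, the one measured step of the same kind, fluoro in place of hydrogen on an aromatic carbon, is a 1.1-fold higher number from compound 1 to compound 3 (0.05 log units; within the scatter). The step of a 1.2-fold higher number from compound 2 to compound 3 (0.09 log units; within the scatter), hydrogen in place of ethyl on an oxygen next to a carbonyl group, is a different kind of change. Since the related step stayed within the scatter, no step beyond it is expected here. The step expected is a 1.0-fold higher number from compound 2 to compound 4 (0.01 log units; within the scatter). Compound 4 is therefore estimated at 41000 nM, between 20000 nM and 85000 nM.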

Compound 4, half-maximal cytotoxic concentration: 21100 nM
For compound 4 the middle estimate is 1.9-fold (0.29 log units) above the measured one, and the stated range covers the measured number.
By their numbers in this assay, from the lowest: compounds 4, 2, 1 and 3 (each within the scatter of the next, the first and the last beyond it).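

In this assay, going from 2,3,6-trifluorobenzyl to 2,3-difluorobenzyl gives a 1.9-fold lower number from compound 2 to compound 4 (0.28 log units; within the scatter), so this position on an aromatic carbon, ortho to a large group, shows no step beyond the scatter on the core of compound 2 either. The exchange between fluoro and hydrogen at this place can now be read on two cores, and the two readings agree: the same change on two cores in this assay, a 1.1-fold higher number (0.05 log units; within the scatter) from compound 1 to compound 3 and a 1.9-fold higher number (0.28 log units; within the scatter) from compound 4 to compound 2, 1.7-fold (0.24 log units) apart, within the scatter of two such steps

The compounds shown leave open whether a chloro group or an amine on this aromatic carbon would give a step beyond the scatter.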